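The source may report more compounds than this note shows. Statements on the series, on what has been measured and on what is new or still open speak of the compounds shown alone.

Three amides sharing the core of compound 1 `CS(=O)(=O)c1ccc(C(=O)NCC(=O)N(Cc2ccccc2)Cc2ccccc2)cc1[N+](=O)[O-]` have been run in an assay on isolated protein for inhibition of vitamin D3 receptor (Homo sapiens), read by fluorescence polarization; on this read-out lower numbers stand for stronger inhibition and higher numbers for weaker inhibition. Compound 1 reaches no number and gives only the assay limit, > 60000 nM. Compound 2 `CC1CCN(C(=O)CCNC(=O)c2ccc(S(C)(=O)=O)c([N+](=O)[O-])c2)CC1` likewise stands at the limit in this assay, > 60000 nM. Compound 3 `CS(=O)(=O)c1ccc(C(=O)NCCCC(=O)N2CCCCC2)cc1[N+](=O)[O-]` also sits at the limit, > 60000 nM. Among the compounds with values here, the single one-place step, a step that the two limits leave unreadable from compound 2 to compound 3, is thus unreadable, and the only evidence available is the limit of > 60000 nM in this assay, at which 3 of the 3 values shown sit. Compound 4 `CS(=O)(=O)c1ccc(C(=O)NCCC(=O)N2CCCc3ccccc32)cc1[N+](=O)[O-]` is the next member; it differs from compound 2 by 1,2,3,4-tetrahydroquinolin-1-yl in place of 4-methylpiperidin-1-yl on a carbonyl carbon. Within the data shown here, no measured step speaks to this change, so no shift beyond the scatter can be foreseen in this assay, and a limit is again the likeliest outcome. The estimate for compound 4 is 80000 nM, between 30000 nM and 300000 nM, an expected step that the limit leaves unreadable from compound 2 to compound 4.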

Compound 4, half-maximal inhibitory concentration: > 60000 nM
Compound 4 ended at the assay's limit (the forecaster's own chance of this, stated with the estimate: 85%); the middle value lies beyond the limit too.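

No step can be read between compound 2 and compound 4; both rest on one result: the limit of > 60000 nM in this assay, at which 4 of the 4 values shown sit. The compounds shown leave open which change to the shared core, if any, would give a number in this assay.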